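The compounds below may be only part of what the source reports. "The series", "measured", "known", "first", "only" and "open" are said of these compounds alone.

Measured compounds:
- compound 1, `CCCCCCCCSC[C@H](NC(C)=O)C(=O)CCl`: 4100 nM
- compound 2, `CCCCCCCCCSC[C@H](NC(C)=O)C(=O)CCl`: 6700 nM

Both compounds share the same core and differ only in the length of the saturated chain attached to the sulfur. In a functional assay on MOLT-3 cells (Homo sapiens) (a lower number here means a stronger inhibitor, a higher number a weaker inhibitor), compound 1 gives 4100 nM and compound 2 gives 6700 nM. Compound 2 carries the larger of the two numbers, but the step of a 1.6-fold higher number from compound 1 to compound 2 (0.21 log units; within the scatter) lies within the scatter, so the two compounds cannot be separated on these data.

Compound 3, `CCCCCCCCCCSC[C@H](NC(C)=O)C(=O)CCl`, continues the same series: relative to compound 2 the change is methyl in place of hydrogen on a saturated chain carbon, nine bonds along the chain from a sulfur. Within the data shown here, the only measured step that bears on this is the one from compound 1 to compound 2, where the chain was lengthened in the same way one position closer to the sulfur, and a 1.6-fold higher number from compound 1 to compound 2 (0.21 log units; within the scatter) resulted, a change too small to count. Lengthening the chain once more is therefore expected to leave this assay largely unchanged, with at most a small drift towards a higher number, as in a 1.3-fold higher number from compound 2 to compound 3 (0.13 log units; within the scatter). The estimate for compound 3 is 9000 nM, within 4000 nM to 22000 nM.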

Compound 3, half-maximal inhibitory concentration: 3400 nM
For compound 3 the middle estimate is 2.6-fold (0.42 log units) above the measured one; the whole stated range lies above it.
By their numbers in this assay, from the lowest: compounds 3, 1 and 2 (each within the scatter of the next).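

In this assay, this position now has a second step to set beside the first: adding one more methyl, nine bonds along the chain from a sulfur, gives a step that also stays within the scatter (a 2.0-fold lower number from compound 2 to compound 3 (0.29 log units; within the scatter)). Counted from the shortest chain shown, the change is ethyl in place of hydrogen, eight bonds along the chain from a sulfur, and that step is also within the scatter (a 1.2-fold lower number from compound 1 to compound 3 (0.08 log units; within the scatter)), so the two added carbons together do not separate the compounds and the three chain lengths cannot be ranked. The two single-carbon steps point in opposite directions, but neither can be read as a real change, which means these data show no trend with chain length and suggest that this assay tolerates these small extensions; no independent measurement is available to explain this result.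

On these data alone, what stays open is whether the number would move beyond the scatter with a much shorter or a much longer chain. A chain ending in an amine or a carboxylic acid is also untested by the compounds shown, so they cannot tell whether this position responds to anything other than a plain saturated chain.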